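Hepatocyte clearance in the amine-substituted series: compound 4

The source may report more compounds than this note shows. Statements on the series, on what has been measured and on what is new or still open speak of the compounds shown alone.

Measured so far:
compound 1 `CC(=O)Nc1cc(Nc2cc(NC3CC3)n3ncc(C#N)c3n2)ccc1N1CC[C@H](N(C)C)C1`: 2.5 uL/min
compound 2 `CC(=O)Nc1cc(Nc2cc(NC3CC3)n3ncc(C#N)c3n2)ccc1NCCCO`: 17 uL/min
compound 3 `CCN(CCN)c1ccc(Nc2cc(NC3CC3)n3ncc(C#N)c3n2)cc1NC(C)=O`: 2 uL/min

In an ADME assay on cells (Hepatocyte, Rattus norvegicus) for metabolic stability (a higher number here means faster removal of the compound, a lower number slower removal), compound 3 holds the lowest of the three numbers, but the step of a 1.3-fold lower number from compound 1 to compound 3 (0.10 log units; within the scatter) lies within the scatter, so compound 1 and compound 3 are not separated. Only compound 2 stands apart: a 6.8-fold higher number from compound 1 to compound 2 (0.83 log units; beyond the scatter) and an 8.5-fold lower number from compound 2 to compound 3 (0.93 log units; beyond the scatter) are both beyond the scatter.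

Compound 4 `CC(=O)Nc1cc(Nc2cc(NC3CC3)n3ncc(C#N)c3n2)ccc1N1CC[C@@H](N)C1` differs from compound 3 by a group of 6 heavy atoms (4 carbon, 2 nitrogen; one five-membered non-aromatic ring with 1 hetero atom) in place of a group of 6 heavy atoms (4 carbon, 2 nitrogen; no ring), on an aromatic carbon. Among the measured compounds shown here, the nearest precedent is compound 1, which also carries a ring amine at this position and gave 2.5 uL/min; the step of a 1.3-fold lower number from compound 1 to compound 3 (0.10 log units; within the scatter) between the ring and chain amines was within the scatter. A step of a 1.5-fold higher number from compound 3 to compound 4 (0.18 log units; within the scatter) is therefore expected, not beyond the scatter. Compound 4 is estimated at 3 uL/min, range 1.5 uL/min to 7 uL/min.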

Compound 4, intrinsic clearance in a liver preparation (reported as CLH), per the amount of preparation that the assay uses: 2.5 uL/min
Compound 4: middle estimate off by 1.2-fold (0.08 log units), on the high side; measured number inside the range.
By their numbers in this assay, from the lowest: compounds 3, 1 and 4 (each within the scatter of the next); then compound 2.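

Removing the two methyl groups from the ring amine leaves the number unmoved, with no change at the digits printed from compound 1 to compound 4 (within the scatter) in this assay. Exchanging the open chain for 3-aminopyrrolidin-1-yl also stays inside the noise, at a 1.3-fold higher number from compound 3 to compound 4 (0.10 log units; within the scatter), so compounds 1, 3 and 4 are not separated, while compound 2 remains the exception, with a 6.8-fold lower number from compound 2 to compound 4 (0.83 log units; beyond the scatter). Nothing available explains why (3-hydroxypropyl)amino stands apart from these groups. Open, as far as these compounds go, is whether a piperidine ring or a carboxylic acid at this position would stay with compounds 1, 3 and 4 or move toward compound 2.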